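The source may hold more compounds than are shown below. What is called first, only, known or untested is meant among the compounds shown, and "the series" means these compounds.

In an ADME assay on RAW264.7 cells (Mus musculus) for cytotoxicity, read by trypan blue exclusion, with a stated time of 48 h (on this read-out higher numbers stand for weaker inhibition of growth and lower numbers for stronger inhibition of growth), compound 2 `Cc1ccc(CNCc2cc(C)n(-c3ccc(Cl)cc3)c2C)cc1` gives 0.1 ug/mL as the lowest of three numbers, and its gaps to the other two lie beyond the scatter. Compound 3 `Cc1cc(CNCc2ccccc2)c(C)n1-c1ccc(F)cc1` stands at 5.6 ug/mL and compound 1 `Cc1cc(/C=N\OCc2ccccc2)c(C)n1-c1ccc(Cl)cc1` at 128 ug/mL in the same test. Compound 4 `Cc1cc(CNOCc2ccccc2)c(C)n1-c1ccc(Cl)cc1` has benzyloxy in place of 4-methylbenzyl on an amine nitrogen and is still unmeasured. For the measured compounds named here, no measured pair shows this change alone. Compound 1 also carries a benzyloxy group, though its link to the core differs, and its 128 ug/mL points upward. A step to a higher number, beyond the scatter, is therefore expected, with the estimated 80-fold higher number from compound 2 to compound 4 (1.90 log units; beyond the scatter) as its size. Compound 4 is estimated at 8 ug/mL with an expected range of 1 ug/mL to 60 ug/mL around that figure.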

Compound 4, concentration for 50% growth inhibition: 133 ug/mL
For compound 4 the middle estimate is 17-fold (1.22 log units) below the measured one, and the stated range ends below it.
By their numbers in this assay, from the lowest: compound 2; then compound 3; then compounds 1 and 4 (each within the scatter of the next).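

For the compounds shown here, on an amine nitrogen, benzyloxy in place of 4-methylbenzyl gives a 1300-fold higher number from compound 2 to compound 4 (3.12 log units; beyond the scatter) in this assay, the first comparison here that isolates one place and shows that this position responds strongly to the change. The two groups have the same count of heavy atoms and one six-membered aromatic ring each, yet benzyloxy brings oxygen and a hydrogen-bond acceptor. No measurement shown explains the size of this step. On these data alone, whether the step follows the oxygen or the lost methyl remains open; a plain benzyl group on this nitrogen, with the rest of compound 2 kept, would separate the two.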